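A few compounds are considered here, and "the series" means these few. Any claim that something is new, unique, unknown or untested is made for them only; others in the source may bear on it.

Of the compounds shown here, three sharing one core have been measured in a functional assay on HCT-8 cells (Homo sapiens) for cytotoxicity; on this read-out lower numbers stand for an effect already at smaller amounts and higher numbers for an effect only at larger amounts of compound. Compound 1 `COC1=C(C)C(=O)/C(=C(O)/C=C/c2ccc(C)cc2)C(=O)C1(C)C` gives 4.1 ug/mL, compound 2 `COC1=C(C)C(=O)/C(=C(O)/C=C/c2ccccc2C)C(=O)C1(C)C` gives 4 ug/mL and compound 3 `CCc1ccc(/C=C/C(O)=C2/C(=O)C(C)=C(OC)C(C)(C)C2=O)cc1` gives 10.5 ug/mL. Compound 3 therefore has the highest number of the three, and its gaps to the other two lie beyond the scatter. The unmeasured compound 4 `COC1=C(C)C(=O)/C(=C(O)/C=C/c2cc(C)cc(C)c2)C(=O)C1(C)C` differs from compound 3 in one group: 3,5-dimethylphenyl in place of 4-ethylphenyl on a double-bonded chain carbon bound to a double-bonded chain carbon.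

Going by the values given here, three measured steps bear on this change. Exchanging 4-methylphenyl for 2-methylphenyl gave a 1.0-fold lower number from compound 1 to compound 2 (0.01 log units; within the scatter), so these two compounds do not separate. The steps that arrive at the 4-ethylphenyl group are modest: a 2.6-fold higher number from compound 1 to compound 3 (0.41 log units; beyond the scatter) and a 2.6-fold higher number from compound 2 to compound 3 (0.42 log units; beyond the scatter). Compound 4 loses that ethyl-bearing group and carries methyl groups instead, as compound 1 and compound 2 do. However, no measured compound has the 3,5-dimethylphenyl group, so the comparison is only partial. In this assay, a modest step towards a lower number is therefore expected, of similar or somewhat smaller size than those two steps. The expected change is a 2.1-fold lower number from compound 3 to compound 4 (0.32 log units; beyond the scatter). For compound 4 the estimated value is 5 ug/mL. The expected range for compound 4 runs from 2.5 ug/mL to 11 ug/mL.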

Compound 4, concentration for half-maximal effect: 2.9 ug/mL
Estimate against measurement, compound 4: 1.7-fold (0.24 log units) above; measured number inside the range.
By their numbers in this assay, from the lowest: compounds 4, 2 and 1 (each within the scatter of the next); then compound 3.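

In this assay, moving from the 4-ethylphenyl group to the 3,5-dimethylphenyl group at this place, on a double-bonded chain carbon bound to a double-bonded chain carbon, gives the step (a 3.6-fold lower number from compound 3 to compound 4 (0.56 log units; beyond the scatter)), although both groups have the same counts of heavy atoms, and so those counts alone do not set the number here. Compound 4 does not separate from the two compounds with a single methyl group on the ring, as shown by the steps (a 1.4-fold lower number from compound 2 to compound 4 (0.14 log units; within the scatter)) and (a 1.4-fold lower number from compound 1 to compound 4 (0.15 log units; within the scatter)), so three different methyl patterns now fall together and, among these four compounds, only compound 3 stands apart. No measurement shown here explains why the 4-ethylphenyl group differs from the methyl-bearing groups.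

The compounds shown leave open whether the higher number belongs to ethyl in general or to ethyl at the 4-position of the ring, and how a longer chain such as propyl would behave there. They also leave open what a ring carrying a methoxy group, a fluorine atom or an amine in place of these carbon-only groups would give.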